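Cytotoxicity notes on two measured compounds and one analogue

The compounds below may be only part of what the source reports. "The series", "measured", "known", "first", "only" and "open" are said of these compounds alone.

Measured so far in an ADME assay on MDBK cells (Bos taurus) for cytotoxicity, read by MTT assay; a higher number here means that more compound is tolerated, a lower number that less compound is tolerated:
compound 1, `OC[C@@H]1[C@@H](O)[C@H](O)[C@@H](O)CN1CCCCCCOc1ccc(C(F)(F)F)cc1`: > 500000 nM
compound 2, `CCCC1CCCCC1OCCCCCCN1C[C@H](O)[C@@H](O)[C@H](O)[C@H]1CO`: 150000 nM

The value for compound 1 in this assay is a limit of the assay and not a number. This is the limit of > 500000 nM in this assay, at which 1 of the 2 values shown sits. For the measured compounds named here, compound 2 gives 150000 nM in this assay, and that is the only actual number in the set; no step between measured compounds is available, so there is no measured guide to the size of any change.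

Compound 3, `OC[C@@H]1[C@@H](O)[C@H](O)[C@@H](O)CN1CCCCCCOc1cc(Cl)ccc1Cl`, has not been measured. Against compound 2 the change is a group of 8 heavy atoms (6 carbon, 2 chlorine; one six-membered aromatic ring of carbon only) in place of a group of 9 heavy atoms (9 carbon; one six-membered non-aromatic ring of carbon only), on an oxygen on a saturated carbon. Compound 3 thereby carries a six-membered aromatic ring of carbon only on the oxygen, as compound 1 does, whereas compound 2 carries a non-aromatic ring there.

Given that compound 1 sits at the limit of > 500000 nM in this assay, at which 1 of the 2 values shown sits, the expectation for compound 3 is a step upward from compound 2, estimated as a 2.7-fold higher number from compound 2 to compound 3 (0.43 log units; beyond the scatter), well beyond the usual scatter. Compound 3 is thus estimated at 400000 nM, with a range from 150000 nM to 1000000 nM, and a fair chance that only a limit is reported.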

Compound 3, half-maximal cytotoxic concentration: 320000 nM
For compound 3 the middle estimate is 1.3-fold (0.10 log units) above the measured one; low and high end bracket the measured number.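

In this assay, placing 2,5-dichlorophenyl on the oxygen in place of the non-aromatic carbon ring group gives a 2.1-fold higher number from compound 2 to compound 3 (0.33 log units; beyond the scatter), the first measured size for a change at this position, and the step is modest. Compound 3 still returns an actual number, so among the compounds shown an aromatic ring of carbon on this oxygen does not by itself carry a compound to the limit of the assay. Compound 1, which carries the same kind of ring on the oxygen with trifluoromethyl in place of the two chlorines, remains a limit of the assay and not a number: the limit of > 500000 nM in this assay, at which 1 of the 3 values shown sits.

The compounds shown do not separate what the aromatic ring contributes from what the two chlorines contribute, as a plain phenyl on the oxygen is not among them. They also leave open how this assay responds to an amine or a carboxylic acid on that ring, or to a longer chain between the oxygen and the shared core.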